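Adding a Second Methoxy to an Inactive Core

The source may report more compounds than this note shows. Statements on the series, on what has been measured and on what is new or still open speak of the compounds shown alone.

Compound 1 `COc1ccc(-c2nnc(-c3c[nH]c4ccccc34)o2)cc1` was tested in a functional assay on MDA-MB-231 cells (Homo sapiens) for cytotoxicity, read by MTT assay; on this read-out lower numbers stand for stronger inhibition and higher numbers for weaker inhibition. In this assay compound 1 gives only a limit, > 1000000 nM. Compound 2 `Clc1ccc(-c2nnc(-c3c[nH]c4ccccc34)o2)cc1`, with chloro in place of methoxy, also gives a limit in this assay, > 1000000 nM. The step from compound 1 to compound 2 is a step that the two limits leave unreadable from compound 1 to compound 2; the two limits the limit of > 1000000 nM in this assay, at which 2 of the 2 values shown sit, leave its size unreadable. Compound 3 `COc1ccc(-c2nnc(-c3c[nH]c4ccccc34)o2)cc1OC` differs from compound 1 by methoxy in place of hydrogen on an aromatic carbon, a methoxy in place of hydrogen on an aromatic carbon. Going by the values given here, no measured step bears on this change. Compound 3 is therefore expected to stay at the limit, estimated at 1000000 nM (range 300000 nM to 3000000 nM). That expectation corresponds to a step of a number no higher from compound 1 to compound 3 (the limit leaves the size open).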

Compound 3, half-maximal inhibitory concentration: > 1000000 nM
Compound 3 ended at the assay's limit; the forecaster's own chance of this, stated with the estimate: 85%; the middle value lies on the limit itself.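

Going by these compounds alone, compound 1 and compound 3 both stop at a limit, so no step between them can be read: the limit of > 1000000 nM in this assay, at which 3 of the 3 values shown sit. Going by these compounds, whether any change to the shared core gives a readable number in this assay stays open.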